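Dropping the Carboxy Group from Compound 1

The source may report more compounds than this note shows. Statements on the series, on what has been measured and on what is new or still open speak of the compounds shown alone.

Measured compounds:
compound 1 `Cn1c(-c2ccc(C(=O)O)cc2)nc2c(NC3CCCC3)ncnc21` — > 30000 nM
compound 2 `CCn1c(-c2ccccc2)nc2c(N)ncnc21` — 3020 nM

Of the compounds shown here, two have been measured in a functional assay on CHO cells for antagonist activity at adenosine receptor A2b (Homo sapiens), read by 33P incorporation, with a stated time of 20 min; a higher number here means a weaker inhibitor, a lower number a stronger inhibitor. Compound 1 `Cn1c(-c2ccc(C(=O)O)cc2)nc2c(NC3CCCC3)ncnc21` returns > 30000 nM, which is a limit of the assay rather than a number. Compound 2 `CCn1c(-c2ccccc2)nc2c(N)ncnc21` gives 3020 nM. On these data alone, compound 1 therefore stands at the limit of > 30000 nM in this assay, at which 1 of the 2 values shown sits, and its true value is unknown. Going by the values given here, no step between measured compounds that differ in a single place is available, so no measured step size guides the next move.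

Compound 3 `Cn1c(-c2ccccc2)nc2c(NC3CCCC3)ncnc21` differs from compound 1 by hydrogen in place of carboxy on an aromatic carbon. Because compound 1 sits at the limit of > 30000 nM in this assay, at which 1 of the 2 values shown sits, the step cannot be read from measured values, but compound 2, also lacking a carboxy group, gives 3020 nM. The step of an at least 10-fold lower number from compound 1 to compound 3 (1.00 log units; beyond the scatter) is expected to run toward stronger inhibition, beyond the usual scatter. Compound 3 is estimated at 3000 nM, expected to lie between 400 nM and 25000 nM.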

Compound 3, inhibition constant: 8510 nM
Beside the measured number, compound 3's estimate is 2.8-fold (0.45 log units) below it, within the range that was stated.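

In this assay, putting hydrogen in place of carboxy on an aromatic carbon, para to a large group, gives an at least 3.5-fold lower number from compound 1 to compound 3 (0.54 log units; beyond the scatter). Going by these compounds alone, this is the first step read at this position, and it shows that the core of compound 1 gives a measurable value once the carboxy group is gone, so carboxy at this place goes with much weaker inhibition than hydrogen. The size of the step is only a bound, because compound 1 stands at a limit of the assay rather than at a number: the limit of > 30000 nM in this assay, at which 1 of the 3 values shown sits.

On these data alone, the true size of the step remains open, as does whether an amide, a methyl ester or a hydroxyl at this place would behave like carboxy or like hydrogen. Compound 2 and compound 3 differ in more than one place, so what their other groups each contribute cannot be read.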